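From Propyl to Trifluoromethoxy: Estimating Compound 4

This account rests on a few compounds, and the source may have more. Where it says the series, first, only, none or still open, it means among the compounds named here.

Measured so far in an assay on isolated protein for inhibition of Rho-associated protein kinase 1 (Homo sapiens), read by scintillation counting, radiometric assay and 33P incorporation, with a stated time of 40 min, in the presence of a further agent that is not named here; on this read-out higher numbers stand for weaker inhibition and lower numbers for stronger inhibition:
- compound 1 `COc1ccc(OCC(=O)Nc2cccc(NC(=O)c3ccc(N(C)C)cc3)c2)cc1F` gives 1820 nM
- compound 2 `Cc1c(OCC(=O)Nc2cccc(NC(=O)c3ccc(N(C)C)cc3)c2)ccc2c(=O)ccoc12` sits at a limit of the assay, > 10000 nM
- compound 3 `CCCc1ccc(C(=O)Nc2cccc(NC(=O)COc3ccc4c(=O)ccoc4c3)c2)cc1` gives 143 nM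

Compound 3 has the lowest of the two real numbers shown. Its nearest neighbour is compound 1, whose number is higher by a gap that lies beyond the usual scatter of this assay. For compound 2 only a limit is known; that is what the limit of > 10000 nM in this assay, at which 1 of the 3 values shown sits, records, and it says nothing more precise than that.

The step to the not yet measured compound 4 `O=C(COc1ccc2c(=O)ccoc2c1)Nc1cccc(NC(=O)c2ccc(OC(F)(F)F)cc2)c1` is a single change: trifluoromethoxy in place of propyl on an aromatic carbon. The rest of the molecule, including the shared core and the amide links, stays as it is in compound 3. Among the measured compounds shown here, no measured pair in this set shows the same change, so there is no directly comparable step to lean on.

The swap replaces one group with another of roughly similar bulk, and nothing in the measured compounds argues for a large move in either direction. The step from compound 3 to compound 4 is therefore expected to be small, a 1.7-fold higher number from compound 3 to compound 4 (0.24 log units; within the scatter), possibly within the scatter or a modest weakening. Compound 4 is estimated at 250 nM, with a likely range from 70 nM to 900 nM.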

Compound 4, half-maximal inhibitory concentration: 869 nM
Beside the measured number, compound 4's estimate is 3.5-fold (0.54 log units) below it; the measured number falls inside the stated range.
By their numbers in this assay, from the lowest: compound 3; then compound 4; then compound 1. At a limit, above all of these: compound 2.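

Putting trifluoromethoxy in place of propyl gives a 6.1-fold higher number from compound 3 to compound 4 (0.78 log units; beyond the scatter) in this assay, which means weaker inhibition and shows that this place on the aromatic ring, para to a large group, responds to what sits on it. Among the compounds shown here, the earlier compounds could not show this: no two of them differed in only one place, so this is the first direct reading of a single change in the set. The entering group has more heavy atoms than propyl and brings one hydrogen-bond acceptor where propyl has none, but nothing measured here tells which of these differences, if either, accounts for the step.

For the compounds shown here, with only two groups compared at this place, it remains open whether a longer chain such as butyl, or a carboxylic acid, would land nearer compound 3 or nearer compound 4. On these data alone, it also remains open whether the same swap would produce a step of similar size on a different core, such as that of compound 1 or compound 2.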